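Swapping a cyclopentyl for an oxolanyl ring on the amine

The source may report more compounds than this note shows. Statements on the series, on what has been measured and on what is new or still open speak of the compounds shown alone.

Measured compounds:
- compound 1 `COc1cc2cc(C#N)ccc2c(OC)c1Oc1cc(NCC(C)(C)C)nc(Nc2ccc(C#N)cc2)n1`: > 125000 nM in an ADME assay on MT4 cells (Homo sapiens) for cytotoxicity, read by MTT assay, with a stated time of 5 days (on this read-out lower numbers stand for higher toxicity in this test and higher numbers for lower toxicity in this test), a limit
- compound 2 `COc1cc2cc(C#N)ccc2c(OC)c1Oc1cc(NC2CCCC2)nc(Nc2ccc(C#N)cc2)n1`: > 125000 nM in this assay, a limit

Compound 2 was tested in this assay and gives only a limit, > 125000 nM. Compound 1 likewise gives only a limit in this assay, > 125000 nM. Going by the values given here, the one step that joins them, a step that the two limits leave unreadable from compound 1 to compound 2, therefore cannot be read. Both compounds sit at the same limit, (the limit of > 125000 nM in this assay, at which 2 of the 2 values shown sit), so compound 2 stands at the edge of what this test can report.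

Compound 3 `COc1cc2cc(C#N)ccc2c(OC)c1Oc1cc(NC2CCOC2)nc(Nc2ccc(C#N)cc2)n1` differs from compound 2 by oxolan-3-yl in place of cyclopentyl on a nitrogen on an aromatic ring. Among the compounds with values here, no measured step bears on this change. Within the data shown here, the only guide is that the two measured compounds, with different groups on that nitrogen, both reach the limit, so no step beyond the scatter is expected in this assay. Compound 3 is therefore expected to give 200000 nM, between 90000 nM and 500000 nM, the step that the limit leaves unreadable from compound 2 to compound 3 being the estimate, most likely reported again only as a limit.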

Compound 3, half-maximal cytotoxic concentration: > 125000 nM
Compound 3 gave a limit, no number (the forecaster's own chance of this, stated with the estimate: 85%); the middle value is on the limit's open side.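

Compound 3 gives only a limit in this assay, > 125000 nM, so the steps joining it to compound 1 and compound 2 cannot be read: the limit of > 125000 nM in this assay, at which 3 of the 3 values shown sit. On these data alone, whether neopentyl, cyclopentyl and oxolan-3-yl on the nitrogen differ at all in this assay stays open.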